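Trimming the Side Chain of a Chemokine Receptor Ligand

This account rests on a few compounds, and the source may have more. Where it says the series, first, only, none or still open, it means among the compounds named here.

Compound 1, `c1ccc(CN(CCCCN(C[C@H]2Cc3ccccc3CN2)[C@H]2CCCc3cccnc32)Cc2ccccc2)cc1`: > 30000 nM
Compound 2, `c1ccc2c(c1)CN[C@@H](CN(CCCCNCC1CCNCC1)[C@H]1CCCc3cccnc31)C2`: > 30000 nM

Of the compounds shown here, two have been measured in a functional assay on cells for agonist activity at C-X-C chemokine receptor type 4 (Homo sapiens), read by fluorescence and calcium flux, with a stated time of 90 s (a lower number here means that less compound is needed, a higher number that more compound is needed for the effect), and neither gives a number. Compound 1 reaches only the limit > 30000 nM in this assay. Compound 2 likewise reaches only the limit > 30000 nM in this assay. For the measured compounds named here, compound 2 therefore stands at the same place as the one other value shown, as the limit of > 30000 nM in this assay, at which 2 of the 2 values shown sit, makes plain; nothing separates the two on the numbers available.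

Compound 3, `CC(C)(CCN)CN(C[C@H]1Cc2ccccc2CN1)[C@H]1CCCc2cccnc21`, is not yet measured. It differs from compound 2 in one place: a group of 6 heavy atoms (5 carbon, 1 nitrogen; no ring) in place of a group of 11 heavy atoms (9 carbon, 2 nitrogen; one six-membered non-aromatic ring with 1 hetero atom), on a saturated chain carbon bound to an amine nitrogen. The entering group carries one hydrogen-bond donor and one acceptor where the leaving group carried two of each, and the ring of the leaving group is gone.

Going by the values given here, with both measured values sitting at a limit, no step of known size exists to lean on. The account expects compound 3 to remain near that limit, with a step from compound 2 to compound 3 of a number no higher from compound 2 to compound 3 (the limit leaves the size open), that is, none beyond the scatter. For compound 3 the estimate in this assay is 30000 nM, within 3000 nM to 100000 nM.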

Compound 3, half-maximal effective concentration: > 30000 nM
Compound 3: a limit, no number (the forecaster's own chance of this, stated with the estimate: 60%); the middle value sits exactly at the limit.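

For the compounds shown here, compound 2 and compound 3 both end at a limit and not at a number in this assay, so no step between them can be read: the limit of > 30000 nM in this assay, at which 3 of the 3 values shown sit.

The compounds shown leave open whether any side chain on the shared core gives a measurable half-maximal effective concentration, and how the two groups exchanged here would compare.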